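The source may hold more compounds than are shown below. What is called first, only, known or untested is meant among the compounds shown, and "the series" means these compounds.

Compound 3 `Cc1ccc2[nH]c(CC(CC(=O)O)c3ccc(Cl)cc3)nc2c1` gives 0% in an assay on isolated protein for inhibition of protein kinase C zeta type (Homo sapiens), read by 33P incorporation, tested at 50 uM (on this read-out lower numbers stand for a weaker effect and higher numbers for a stronger effect at the one concentration tested), and stands level with compound 1 `O=C(O)CC(Cc1nc2cc(F)ccc2[nH]1)c1ccc(Cl)cc1`, which gives 0%, the two together the lowest of the three numbers; compound 2 `O=C(O)CC(Cc1nc2cc(C(F)(F)F)ccc2[nH]1)c1ccc(Cl)cc1` gives 35%. Compound 4 `CCc1ccc2[nH]c(CC(CC(=O)O)c3ccc(Cl)cc3)nc2c1` differs from compound 3 by methyl in place of hydrogen on a saturated chain carbon bound to an aromatic carbon. Among the measured compounds shown here, no measured step changes a group at this place. For the measured compounds named here, the steps that bear on it are no change at the digits printed from compound 1 to compound 3 (within the scatter) and a number 35 percentage points lower from compound 2 to compound 3 (beyond the scatter); the only step beyond the scatter is a number 35 percentage points higher from compound 1 to compound 2 (beyond the scatter), which brings in trifluoromethyl, not an ethyl chain. Compound 4 is therefore expected to move little from compound 3, an expected step of a number 5 percentage points higher from compound 3 to compound 4 (within the scatter) that lies within the scatter. Compound 4 is estimated at 5%, between 0% and 20%.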

Compound 4, a percentage reported as inhibition, at one concentration (the size of the read-out at that concentration, not a potency): 0%
Estimate against measurement, compound 4: 5 percentage points above; the range from low to high includes it.
By their numbers in this assay, from the lowest: compounds 1, 3 and 4 (each within the scatter of the next); then compound 2.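

In this assay, extending methyl to ethyl gives no change at the digits printed from compound 3 to compound 4 (within the scatter), so this first change on a saturated chain carbon bound to an aromatic carbon leaves the read-out where it was. Ethyl on the aromatic carbon also reads the same as fluoro, with no change at the digits printed from compound 1 to compound 4 (within the scatter), while a number 35 percentage points lower from compound 2 to compound 4 (beyond the scatter) leaves trifluoromethyl as the only group here set apart from the others. No available evidence accounts for these results. On these data alone, whether a longer chain, an amine or a carboxylic acid at this place would raise the number remains open.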